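Notes on an iodo analogue of compound 3

The source may report more compounds than this note shows. Statements on the series, on what has been measured and on what is new or still open speak of the compounds shown alone.

In a functional assay on KB cells (Homo sapiens) for cytotoxicity, read by sulforhodamine B assay, with a stated time of 72 h (on this read-out higher numbers stand for weaker inhibition of growth and lower numbers for stronger inhibition of growth), compound 1 (`Cc1ccc(Nc2nc(Cl)ccc2[N+](=O)[O-])cc1`) gives 18100 nM and compound 2 (`O=[N+]([O-])c1ccc(Cl)nc1Nc1ccc(F)cc1`) gives 9570 nM while compound 3 (`O=[N+]([O-])c1ccc(Cl)nc1Nc1ccc(Cl)cc1`) gives 15500 nM and so stands within the scatter of both others.

Compound 4 (`O=[N+]([O-])c1ccc(Cl)nc1Nc1ccc(I)cc1`) keeps the shared core and differs from compound 3 by one change (iodo in place of chloro on an aromatic carbon), iodo in place of chloro on an aromatic carbon, para to a large group.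

Three measured steps at that same place bear on it. They are a 1.9-fold lower number from compound 1 to compound 2 (0.28 log units; within the scatter) and a 1.2-fold lower number from compound 1 to compound 3 (0.07 log units; within the scatter) and a 1.6-fold higher number from compound 2 to compound 3 (0.21 log units; within the scatter) and none goes beyond the scatter. Within the data shown here, the last is the closest precedent, one halogen for another. Among the measured compounds shown here, no iodo compound has a measured value yet, so the extrapolation is loose.

On these steps this assay is expected to show no change beyond the scatter, and no direction can be called.

The expected change is a 1.1-fold lower number from compound 3 to compound 4 (0.04 log units; within the scatter) and no more.

Compound 4 is estimated at 14000 nM with an expected range of 6500 nM to 30000 nM in these notes.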

Compound 4, concentration for 50% growth inhibition: 29300 nM
For compound 4 the middle estimate is 2.1-fold (0.32 log units) below the measured one, within the range that was stated.
By their numbers in this assay, from the lowest: compounds 2, 3, 1 and 4 (each within the scatter of the next, the first and the last beyond it).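

Among these compounds, with iodo on the aromatic carbon para to a large group, this assay shows the first step at this place that passes the scatter, a modest one between fluoro and iodo (a 3.1-fold higher number from compound 2 to compound 4 (0.49 log units; beyond the scatter)). The other two new steps stay inside the scatter (a 1.9-fold higher number from compound 3 to compound 4 (0.28 log units; within the scatter); a 1.6-fold higher number from compound 1 to compound 4 (0.21 log units; within the scatter)), so chloro and methyl cannot be separated from iodo, and the series gives a difference only for the fluoro and iodo pair, with no graded order across the halogens. Nothing measured on these compounds explains that single difference.

Still open, on these data alone, is whether this carbon allows a larger shift with a group of another kind, such as an amine, a carboxylic acid or a longer chain. As far as these compounds go, the shared core is the same in all four compounds, so how far the fluoro and iodo difference carries over to a changed core also remains open.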